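Trifluoromethyl for methoxy on a shared core

The source may hold more compounds than are shown below. What is called first, only, known or untested is meant among the compounds shown, and "the series" means these compounds.

Compound 1 `COc1ccc(/C=C/C(=O)c2c(O)cc(O)cc2OC)cc1` gives 47700 nM
Compound 2 `COc1ccc(/C=C/C(=O)c2c(O)cc(O)cc2OC)cc1OC` gives 49500 nM

Among the compounds with values here, both values come from a functional assay on HeLa cells (Homo sapiens) for inhibition, read by MTT assay, with a stated time of 72 h (a higher number here means a weaker inhibitor, a lower number a stronger inhibitor), and lie within the scatter of each other, so compound 1 stands level with its only neighbour. Compound 3 `COc1cc(O)cc(O)c1C(=O)/C=C/c1ccc(C(F)(F)F)cc1` is still unmeasured and differs from compound 1 in one place, with trifluoromethyl in place of methoxy on an aromatic carbon, para to a large group (trifluoromethyl in place of methoxy on an aromatic carbon). Within the data shown here, the only measured step is a different change, methoxy in place of hydrogen on an aromatic carbon, and it stays within the scatter (a 1.0-fold higher number from compound 1 to compound 2 (0.02 log units; within the scatter)). It is a weak guide, but in this assay no step beyond the scatter is expected, and no direction is favoured. The estimated step is small (a 1.2-fold lower number from compound 1 to compound 3 (0.08 log units; within the scatter)). For compound 3 the expected value is 40000 nM with an estimated range from 15000 nM to (100000 nM).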

Compound 3, half-maximal inhibitory concentration: 9500 nM
The estimate for compound 3 lay 4.2-fold (0.62 log units) above the measured number; measured number outside the range, below it.
By their numbers in this assay, from the lowest: compound 3; then compounds 1 and 2 (each within the scatter of the next).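

In this assay, trifluoromethyl in place of methoxy on an aromatic carbon, para to a large group, gives a 5.0-fold lower number from compound 1 to compound 3 (0.70 log units; beyond the scatter). Within the data shown here, this shows that the number can respond to a change at this position, whereas the only earlier step, a 1.0-fold higher number from compound 1 to compound 2 (0.02 log units; within the scatter), stayed within the scatter. No measurement shown here accounts for the step.

Going by these compounds, it remains open what a nitrile or an amine would give at this position. On these data alone, it is also open whether hydrogen there would give a number closer to compound 1 or to compound 3.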